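Pyrazolo-fused series: phenethyl for 4-chlorophenyl at the aryl position

This account rests on a few compounds, and the source may have more. Where it says the series, first, only, none or still open, it means among the compounds named here.

Measured so far in a functional assay on A549 cells (Homo sapiens) for cytotoxicity, read by sulforhodamine B assay, with a stated time of 2 days, tested at 100 uM; a higher number here means more inhibition at the concentration tested (going by the name of the read-out), a lower number less inhibition:
- compound 1 `O=C(Nn1c(-c2cccc([N+](=O)[O-])c2)nc2c(-c3ccc(Cl)cc3)n[nH]c2c1=O)c1cccnc1`: 19.7%
- compound 2 `COc1cccc(-c2nc3c(-c4ccc(Cl)cc4)n[nH]c3c(=O)n2NC(=O)c2ccncc2)c1`: 46%

Compound 1 stands lowest of the two numbers in this assay; compound 2 is the nearer and only comparator, and its value lies above that of compound 1 by more than the usual scatter. For the measured compounds named here, compound 2 differs from compound 1 in more than one place, so no single-change step exists among the measured compounds.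

Compound 3 `O=C(Nn1c(-c2cccc([N+](=O)[O-])c2)nc2c(CCc3ccccc3)n[nH]c2c1=O)c1cccnc1` is not yet measured. It differs from compound 1 as follows: phenethyl in place of 4-chlorophenyl on an aromatic carbon. Going by the values given here, no measured step of this kind is available, so the expectation rests on compound 1 alone. In this assay the step from compound 1 to compound 3 is expected to be small, a number 2.3 percentage points higher from compound 1 to compound 3 (within the scatter), in either direction and not clearly beyond the scatter. For compound 3 the value is estimated at 22%, within a range from 5% to 45%.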

Compound 3, a percentage reported as inhibition, at one concentration (the size of the read-out at that concentration, not a potency): 19%
The estimate for compound 3 lay 3 percentage points above the measured number, within the range that was stated.
By their numbers in this assay, from the lowest: compounds 3 and 1 (each within the scatter of the next); then compound 2.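

In this assay the position on an aromatic carbon of the five-membered aromatic ring accepts phenethyl in place of 4-chlorophenyl without separating the two compounds: a number 0.7 percentage points lower from compound 1 to compound 3 (within the scatter). With the rest of compound 1 held fixed, neither the chlorine nor the direct attachment of the aromatic ring to the core is needed to stay at this level of inhibition. Nothing on hand offers an explanation for this result.

Going by these compounds, it remains open whether an amine, a carboxylic acid or a longer chain ending in phenyl at this position would move the number away from that of compound 1. On these data alone, it is also open whether the same exchange would leave compound 2 equally unchanged, since that compound sits higher in this assay.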